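The compounds below may be only part of what the source reports. "The series", "measured", "known", "first", "only" and "open" are said of these compounds alone.

Two compounds of the series carry numbers in a functional assay on IGROV-1 cells (Homo sapiens) for inhibition; on this read-out higher numbers stand for weaker inhibition of growth and lower numbers for stronger inhibition of growth. Compound 1 (`NS(=O)(=O)c1ccc(/C=C/c2ccc(O)c(O)c2)cc1`) gives 4490 nM. Compound 2 (`NS(=O)(=O)c1ccc(/C=C/c2ccc(F)cc2)cc1`) gives 20900 nM, the higher of the two numbers, and its gap to compound 1 lies beyond the scatter. Compound 2 therefore stands as the weaker inhibitor of growth so far. The next compound is compound 3 (`NS(=O)(=O)c1ccc(/C=C/c2ccc(O)cc2)cc1`), and the change from compound 2 is hydroxy in place of fluoro on an aromatic carbon. Within the data shown here, no measured pair shows this change alone, so the expectation rests on thin ground. Among the measured compounds shown here, the only measured compound bearing hydroxy is compound 1, at 4490 nM. In this assay, a moderate move toward lower numbers is therefore expected, somewhat beyond the scatter. The expected change is a 2.6-fold lower number from compound 2 to compound 3 (0.42 log units; beyond the scatter). Compound 3 is estimated at 8000 nM, with an expected range of 3000 nM to 20000 nM.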

Compound 3, concentration for 50% growth inhibition: 20300 nM
The estimate for compound 3 lay 2.5-fold (0.40 log units) below the measured number; measured number above the stated range.
By their numbers in this assay, from the lowest: compound 1; then compounds 3 and 2 (each within the scatter of the next).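

In this assay hydroxy in place of fluoro on an aromatic carbon para to a large group leaves the number unchanged (a 1.0-fold lower number from compound 2 to compound 3 (0.01 log units; within the scatter)), so this position does not tell the two groups apart. Among these compounds, the single hydroxy of compound 3 does not reproduce the lower number of compound 1: hydrogen in place of hydroxy gives a clear rise (a 4.5-fold higher number from compound 1 to compound 3 (0.66 log units; beyond the scatter)), which ties that lower number to the second hydroxy of compound 1. No measurement bearing on the reason for either result is available.

Open, on these data alone, is whether an amino or methoxy group at this position would separate from hydroxy and fluoro. Also open, as far as these compounds go, is whether the second hydroxy of compound 1 lowers the number on its own or only alongside the first.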